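Capping the Phenol: From Compound 1 to Compound 3

A few compounds are considered here, and "the series" means these few. Any claim that something is new, unique, unknown or untested is made for them only; others in the source may bear on it.

Measured so far:
- compound 1, `O=C(Nc1cccc(-n2cc(-c3ccncc3)c(-c3cc(O)cc(Cl)c3)n2)c1)Nc1ccc(Cl)c(C(F)(F)F)c1`: 56%
- compound 2, `O=C(Nc1cccc(-n2cc(-c3ccncc3)c(-c3cc(O)cc(Cl)c3)n2)c1)Nc1ccc(Cl)c(Cl)c1`: 72%

Of the compounds shown here, two have been measured in a functional assay on KM12 cells (Homo sapiens) for inhibition, read by sulforhodamine B assay, with a stated time of 48 h, tested at 1 uM; a lower number here means a stronger effect, a higher number a weaker effect of the compound at the concentration tested. Compound 1 gives 56% and stands as the lowest of the two numbers, its nearest neighbour being compound 2 with 72%. Within the data shown here, the one step between them, a number 16 percentage points higher from compound 1 to compound 2 (beyond the scatter), concerns the group on the other aromatic ring, not the phenol.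

Compound 3, `COc1cc(Cl)cc(-c2nn(-c3cccc(NC(=O)Nc4ccc(Cl)c(C(F)(F)F)c4)c3)cc2-c2ccncc2)c1`, is not yet measured. It differs from compound 1 in a single place: methyl in place of hydrogen on an oxygen on an aromatic ring. Among the measured compounds shown here, no measured step touches this position; the only step on record, a number 16 percentage points higher from compound 1 to compound 2 (beyond the scatter), changes a different ring and so does not show how the oxygen here behaves. The expectation for compound 3 therefore rests on the spread of the two measured numbers alone. Compound 3 is estimated to give 68%, with a range from 45% to 90%. This means an expected step of a number 12 percentage points higher from compound 1 to compound 3 (beyond the scatter), a drift toward a weaker effect that may or may not exceed the scatter.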

Compound 3, a percentage reported as activity, at one concentration (the size of the read-out at that concentration, not a potency): 33%
Beside the measured number, compound 3's estimate is 35 percentage points above it, outside the stated range (below it).
By their numbers in this assay, from the lowest: compound 3; then compound 1; then compound 2.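

In this assay, the change from hydroxy to methoxy on the 3-chloro-5-hydroxyphenyl group gives a number 23 percentage points lower from compound 1 to compound 3 (beyond the scatter), so the hydrogen on this oxygen is not needed for the effect seen here, and replacing it with methyl gives a stronger effect at the concentration tested. The earlier pair differed only on the other aromatic ring and so said nothing about this oxygen, whereas this step shows that the read-out also responds to a change at this position. No measurement at hand gives a reason for this shift.

Going by these compounds, one step shows only one replacement, so it remains open whether the stronger effect is particular to methyl or would also appear with a longer chain such as ethyl on the oxygen, or with an amine in place of the methoxy group. Also open, on these data alone, is whether methoxy would give a similar step with chloro in place of trifluoromethyl on the other ring, as in compound 2, and whether the stronger effect seen at this one concentration would also hold at other concentrations.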